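The source may hold more compounds than are shown below. What is called first, only, known or untested is meant among the compounds shown, and "the series" means these compounds.

Measured compounds in a functional assay on SK-BR-3 cells (Homo sapiens) for antiproliferative activity, read by MTT assay, with a stated time of 72 h; on this read-out lower numbers stand for stronger inhibition and higher numbers for weaker inhibition:

Compound 1 `C/C=C1/[C@H](O[C@@H]2O[C@H](CO)[C@@H](O)[C@H](O)[C@H]2O)OC=C(C(=O)OC)[C@H]1CC(=O)OCCCc1ccc(OC)c(OC)c1` gives > 20000 nM, which is a limit of the assay and not a number.
Compound 2 `C/C=C1/[C@H](O[C@@H]2O[C@H](COC(C)=O)[C@@H](OC(C)=O)[C@H](OC(C)=O)[C@H]2OC(C)=O)OC=C(C(=O)OC)[C@H]1CC(=O)O` gives > 15000 nM, likewise a limit.
Compound 3 `C/C=C1/[C@H](O[C@@H]2O[C@H](COC(C)=O)[C@@H](OC(C)=O)[C@H](OC(C)=O)[C@H]2OC(C)=O)OC=C(C(=O)OC)[C@H]1CC(=O)OCCCC` gives > 15000 nM, again a limit.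

Among the compounds with values here, compound 1 thus stands only at a limit in this assay; the two further values shown are limits as well, so no compound in the set has a number. Within the data shown here, the single step between compounds that differ in one place, a step that the two limits leave unreadable from compound 2 to compound 3, cannot be read in size or direction, since both ends sit at the limit of > 15000 nM in this assay, at which 2 of the 3 values shown sit. Compound 1 sits at the limit of > 20000 nM in this assay, at which 1 of the 3 values shown sits.

The unmeasured compound 4 `C/C=C1/[C@H](O[C@@H]2O[C@H](CO)[C@@H](O)[C@H](O)[C@H]2O)OC=C(C(=O)OC)[C@H]1CC(=O)OCCc1ccccc1` differs from compound 1 by phenyl in place of 3,4-dimethoxybenzyl on a saturated chain carbon, two bonds along the chain from an oxygen next to a carbonyl group. Among the measured compounds shown here, no measured step bears on this change directly; the only comparable change, on the same oxygen of the shared core, is the unreadable step from compound 2 to compound 3. Nothing in the set shows any ester variation leaving the limit, so no step beyond the scatter is expected in this assay in either direction. For compound 4 the expectation is therefore a value near the limit, estimated at 20000 nM, ranging from 5000 nM to 60000 nM, and the expected step from compound 1 is a number no higher from compound 1 to compound 4 (the limit leaves the size open), most likely again reported only as a limit.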

Compound 4, half-maximal inhibitory concentration: 11000 nM
Compound 4: the middle estimate sits 1.8-fold (0.26 log units) above what was measured; the measured number falls inside the stated range.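

In this assay, within the data shown here, compound 4 gives 11000 nM, the only number so far. A variation of the ester chain on the shared core can thus bring a compound off the limit in this assay. Phenyl in place of 3,4-dimethoxybenzyl on a saturated chain carbon, two bonds along the chain from an oxygen next to a carbonyl group, gives an at least 1.8-fold lower number from compound 1 to compound 4 (0.25 log units; that floor lies within the scatter), so the printed size is a floor only and does not by itself establish a change beyond the scatter. From the compounds shown here alone, the true size of the step stays open, as compound 1 stands only at a limit and not at a number: the limit of > 20000 nM in this assay, at which 1 of the 4 values shown sits.

The step from compound 2 to compound 3 cannot be read, and the acetylated sugar series therefore says nothing yet about the ester chain: the limit of > 15000 nM in this assay, at which 2 of the 4 values shown sit. Going by these compounds, whether a single methoxy group on the phenyl ring, a longer chain carrying the phenyl, or an amide in place of the ester would move the number further from the limit remains open.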